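Ethyl for Methoxy on a Weakly Cytotoxic Aryl Amide

The source may report more compounds than this note shows. Statements on the series, on what has been measured and on what is new or still open speak of the compounds shown alone.

Compound 1 `CNC(=O)c1cc(Oc2ccc(NC(=O)c3cc(-c4ccc(OC)cc4)ncn3)cc2F)ccn1` was tested in a functional assay on A549 cells (Homo sapiens) for cytotoxicity, read by MTT assay, with a stated time of 72 h (a lower number here means a stronger inhibitor, a higher number a weaker inhibitor), and compound 1 gives 34500 nM. Among the three compounds measured so far, compound 1 sits at the weak end: its number and that of compound 3 `CNC(=O)c1cc(Oc2ccc(NC(=O)c3nccc(-c4ccc(C)cc4)n3)cc2F)ccn1`, which gives 33200 nM, lie within the usual scatter of each other, while compound 2 `CNC(=O)c1cc(Oc2ccc(NC(=O)c3nccc(-c4ccc(OC)cc4)n3)cc2F)ccn1`, which gives 16600 nM, lies beyond it. Compounds 2 and 3 share a core that differs from that of compound 1 in the arrangement of the two ring nitrogens, and between them one measured step is known: a 2.0-fold higher number from compound 2 to compound 3 (0.30 log units; within the scatter).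

Compound 4 `CCc1ccc(-c2cc(C(=O)Nc3ccc(Oc4ccnc(C(=O)NC)c4)c(F)c3)ncn2)cc1` carries the core of compound 1 with one change: ethyl in place of methoxy on an aromatic carbon. Among the compounds with values here, the only measured step that bears on this is the one from compound 2 to compound 3, where methyl took the place of methoxy on the same aromatic carbon, and that step stayed within the scatter. Replacing methoxy with ethyl is a change of the same kind, so no step beyond the scatter is expected in this assay in either direction; the expected step is a 1.2-fold higher number from compound 1 to compound 4 (0.06 log units; within the scatter).

Compound 4 is therefore estimated at 40000 nM, within a range from 15000 nM to 100000 nM.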

Compound 4, half-maximal inhibitory concentration: 3390 nM
Estimate against measurement, compound 4: 12-fold (1.07 log units) above; measured number outside the range, below it.
By their numbers in this assay, from the lowest: compound 4; then compounds 2, 3 and 1 (each within the scatter of the next, the first and the last beyond it).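

Changing 4-methoxyphenyl to 4-ethylphenyl gives a 10-fold lower number from compound 1 to compound 4 (1.01 log units; beyond the scatter) in this assay, which shows that this place, para to a large group, can strongly affect the read-out. The earlier change of methoxy to methyl, a 2.0-fold higher number from compound 2 to compound 3 (0.30 log units; within the scatter) on the other core, stayed within the scatter and gave no sign of a shift this large. The two steps differ in both the incoming group and the core, so the compounds shown cannot tell which difference matters, and no measurement shown explains why ethyl reads so differently from methoxy here.

Going by these compounds, it remains open whether ethyl would bring a similar drop in the number on the other core, and whether methyl on the core of compound 1 would behave like ethyl. Also open, on these data alone, is how a longer chain such as propyl, or an amine or a carboxylic acid at the same place, would read in this assay and so whether the trend continues beyond ethyl.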